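This account rests on a few compounds, and the source may have more. Where it says the series, first, only, none or still open, it means among the compounds named here.

Among the measured compounds shown here, compound 2, `CCCOc1cccnc1-c1ccc(C(=O)Nc2ccc(C(C)(C)C)cc2)cc1`, gives 62 nM in a functional assay for antagonist activity at transient receptor potential cation channel subfamily V member 1 (Homo sapiens), read by FLIPR (on this read-out higher numbers stand for weaker inhibition and lower numbers for stronger inhibition), which places it second highest of the three numbers measured so far. Compound 1, `CC(C)(C)c1ccc(NC(=O)c2ccc(-c3ccccn3)cc2)cc1`, gives 11 nM in this assay, and compound 3, `CC(C)(C)c1ccc(NC(=O)c2ccc(-c3ncccc3-c3ncc[nH]3)cc2)cc1`, gives 3670 nM in this assay. Compound 4, `Cc1nnc(-c2cccnc2-c2ccc(C(=O)Nc3ccc(C(C)(C)C)cc3)cc2)o1`, is not yet measured; it differs from compound 2 in one place: 5-methyl-1,3,4-oxadiazol-2-yl in place of propoxy on an aromatic carbon.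

For the measured compounds named here, three measured steps bear on this change. The step of a 5.6-fold higher number from compound 1 to compound 2 (0.75 log units; beyond the scatter) shows that propoxy in this position already costs potency. The step of a 330-fold higher number from compound 1 to compound 3 (2.52 log units; beyond the scatter) and the step of a 59-fold higher number from compound 2 to compound 3 (1.77 log units; beyond the scatter) show that a five-membered aromatic ring in the same position costs far more. The change to compound 4 likewise brings a five-membered aromatic ring in place of propoxy, so the step from compound 2 to compound 3 is the closest guide, and a step in the direction of weaker inhibition is expected in this assay, though its size is uncertain. Compound 4 is therefore expected to give about 600 nM in this assay, with a range from 120 nM to 3000 nM, an expected step of a 9.7-fold higher number from compound 2 to compound 4 (0.99 log units; beyond the scatter).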

Compound 4, half-maximal inhibitory concentration: 387 nM
Estimate against measurement, compound 4: 1.6-fold (0.19 log units) above, within the range that was stated.
By their numbers in this assay, from the lowest: compound 1; then compound 2; then compound 4; then compound 3.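

In this assay, a five-membered aromatic ring at this position does not carry one fixed cost: 5-methyl-1,3,4-oxadiazol-2-yl in place of 1H-imidazol-2-yl gives a 9.5-fold lower number from compound 3 to compound 4 (0.98 log units; beyond the scatter). Even so, 5-methyl-1,3,4-oxadiazol-2-yl in place of propoxy still weakens inhibition, with a 6.2-fold higher number from compound 2 to compound 4 (0.80 log units; beyond the scatter), so neither of the two rings matches propoxy on this carbon. Against hydrogen the loss remains large, with a 35-fold higher number from compound 1 to compound 4 (1.55 log units; beyond the scatter), and all three groups placed on this aromatic carbon give higher numbers than hydrogen does.

Nothing measured here says why the two rings differ. On these data alone, whether a methoxy group or an amine on this carbon would come closer to hydrogen than propoxy does remains open.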